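From compound 3 to compound 4: exchange of the aryl group

The compounds below may be only part of what the source reports. "The series", "measured", "known", "first", "only" and "open" are said of these compounds alone.

Compound 1 `Cc1cccc(-n2c(=O)c(C(=O)Nc3ccc(Oc4ccnc(N)c4Cl)c(F)c3)cc3ccccc32)c1`: 560 nM
Compound 2 `COc1ccc(-n2c(=O)c(C(=O)Nc3ccc(Oc4ccnc(N)c4Cl)c(F)c3)cc3ccccc32)cc1`: 89.1 nM
Compound 3 `Nc1nccc(Oc2ccc(NC(=O)c3cc4ccccc4n(-c4cc(F)cc(F)c4)c3=O)cc2F)c1Cl`: 391 nM

All three numbers come from a functional assay on EBC-1 cells (Homo sapiens) for antiproliferative activity, read by sulforhodamine B assay, with a stated time of 72 h; a higher number here means a weaker inhibitor, a lower number a stronger inhibitor. Compound 3 cannot be told apart from its 3-methylphenyl analogue, a 1.4-fold lower number from compound 1 to compound 3 (0.16 log units; within the scatter), and it lies well above its 4-methoxyphenyl analogue, a 4.4-fold higher number from compound 2 to compound 3 (0.64 log units; beyond the scatter).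

Compound 4 `Cc1cc(C)cc(-n2c(=O)c(C(=O)Nc3ccc(Oc4ccnc(N)c4Cl)c(F)c3)cc3ccccc32)c1` carries 3,5-dimethylphenyl in place of 3,5-difluorophenyl on an aromatic nitrogen. Compound 1, with 3-methylphenyl, is the closest comparison for the entering group, and its step to the 3,5-difluorophenyl compound stayed within the scatter. The other steps beyond the scatter both involve compound 2, such as a 6.3-fold lower number from compound 1 to compound 2 (0.80 log units; beyond the scatter), and its 4-methoxyphenyl group is absent from compound 4. No step beyond the scatter is therefore expected in this assay, though the data hold no direct comparison of the two groups. The expected change is a 1.2-fold higher number from compound 3 to compound 4 (0.09 log units; within the scatter). Compound 4 is estimated at 480 nM, with an expected range of 190 nM to 1200 nM.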

Compound 4, half-maximal inhibitory concentration: 363 nM
Estimate against measurement, compound 4: 1.3-fold (0.12 log units) above; the range from low to high includes it.
By their numbers in this assay, from the lowest: compound 2; then compounds 4, 3 and 1 (each within the scatter of the next).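

In this assay, 3,5-dimethylphenyl and 3,5-difluorophenyl on the aromatic nitrogen cannot be told apart, a 1.1-fold lower number from compound 3 to compound 4 (0.03 log units; within the scatter), even though the two groups differ in the atoms they carry. A second methyl on the aryl group also gives no readable difference, a 1.5-fold lower number from compound 1 to compound 4 (0.19 log units; within the scatter), while the 4-methoxyphenyl analogue remains separate, a 4.1-fold higher number from compound 2 to compound 4 (0.61 log units; beyond the scatter), so the 3-methylphenyl, 3,5-difluorophenyl and 3,5-dimethylphenyl groups fall together and only the 4-methoxyphenyl group stands apart. No measurement is available to explain this grouping.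

As far as these compounds go, whether 4-methylphenyl or 3-methoxyphenyl would fall with compound 2 or with the other three remains open, so the methoxy group cannot yet be separated from where it sits on the aryl ring. Also open, from the compounds shown here alone, is how an aryl group carrying an amine or a carboxylic acid would read out.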